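Positional shift of the trifluoromethyl on the aryl urea

A few compounds are considered here, and "the series" means these few. Any claim that something is new, unique, unknown or untested is made for them only; others in the source may bear on it.

Measured compounds in a functional assay on MCF7 cells (Homo sapiens) for inhibition, read by MTT assay, with a stated time of 72 h; on this read-out higher numbers stand for weaker inhibition and lower numbers for stronger inhibition:
compound 1 `COc1cc(NC(C)CCCNC(=O)NNC(=O)Nc2cc(C(F)(F)F)cc(C(F)(F)F)c2)c2ncccc2c1` gives 2400 nM;
compound 2 `COc1cc(NC(C)CCCNC(=O)Nc2ccc(C(F)(F)F)cc2)c2ncccc2c1` gives 1900 nM;
compound 3 `COc1cc(NC(C)CCCNC(=O)Nc2cccc(O)c2)c2ncccc2c1` gives 11000 nM.

Compound 2 has the lowest number of the three in this assay, though compound 1 sits within the scatter of it and only compound 3 lies clearly apart, as the step of a 5.8-fold higher number from compound 2 to compound 3 (0.76 log units; beyond the scatter) shows. The unmeasured compound 4 `COc1cc(NC(C)CCCNC(=O)Nc2cccc(C(F)(F)F)c2)c2ncccc2c1` differs from compound 2 in one place: 3-(trifluoromethyl)phenyl in place of 4-(trifluoromethyl)phenyl on an amide-type nitrogen.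

For the measured compounds named here, the only measured step at this position is the one to compound 3, which replaces the whole group with 3-hydroxyphenyl and weakens inhibition modestly. Going by the values given here, no measured pair changes only the position of a trifluoromethyl on this ring, so that step gives little guidance beyond indicating that the aryl group matters. The change to compound 4 keeps the same atoms, so a smaller shift is expected than in the step to compound 3. For compound 4 the expected step is a 1.4-fold higher number from compound 2 to compound 4 (0.14 log units; within the scatter), with a slight lean towards weaker inhibition. Compound 4 is therefore estimated at 2600 nM, within a range of 1000 nM to 7000 nM.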

Compound 4, half-maximal inhibitory concentration: 3300 nM
The estimate for compound 4 lay 1.3-fold (0.10 log units) below the measured number, within the range that was stated.
By their numbers in this assay, from the lowest: compounds 2, 1 and 4 (each within the scatter of the next); then compound 3.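

In this assay, 3-(trifluoromethyl)phenyl in place of 4-(trifluoromethyl)phenyl on the amide-type nitrogen gives a 1.7-fold higher number from compound 2 to compound 4 (0.24 log units; within the scatter) and so leaves the read-out unchanged within the scatter, which means this swap of isomeric groups does not separate the two compounds. Trifluoromethyl in place of hydroxy on an aromatic carbon gives a 3.3-fold lower number from compound 3 to compound 4 (0.52 log units; beyond the scatter) and isolates a change of group alone, which the earlier step to compound 3 could not do because it altered the group and its placement together. No measured property is available to explain the size of either step.

From the compounds shown here alone, whether a 3-aminophenyl or a 3-carboxyphenyl group would read like the 3-hydroxyphenyl of compound 3 or the 3-(trifluoromethyl)phenyl of compound 4 remains open. Also open, going by these compounds, is whether 4-hydroxyphenyl would match 3-hydroxyphenyl in the way the two trifluoromethyl isomers match each other.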